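Replacing 1,2-thiazol-4-yl with 1-methyl-1H-pyrazol-4-yl

The source may hold more compounds than are shown below. What is called first, only, known or untested is meant among the compounds shown, and "the series" means these compounds.

Of the compounds shown here, two have so far been read in a functional assay on MCF7 cells (Homo sapiens) for antiproliferative activity, read by CellTiter-Glo, with a stated time of 5 days (on this read-out lower numbers stand for stronger inhibition and higher numbers for weaker inhibition), with a shared core. Compound 1 (`CC/C(=C(/c1ccc(/C=C/C(=O)O)cc1)c1ccc2nncn2c1)c1ccccc1`) reports > 500 nM and this is a limit, not a number. For the measured compounds named here, compound 2 (`CC/C(=C(/c1ccc(/C=C/C(=O)O)cc1)c1ccc(-c2cnsc2)cc1)c1ccccc1`) gives 120 nM as the only actual number, so it stands as the sole numeric reference point. Compound 3 (`CC/C(=C(/c1ccc(/C=C/C(=O)O)cc1)c1ccc(-c2cnn(C)c2)cc1)c1ccccc1`) has 1-methyl-1H-pyrazol-4-yl in place of 1,2-thiazol-4-yl on an aromatic carbon and each group is one five-membered aromatic ring with 2 hetero atoms. Going by the values given here, no measured step covers this exchange. Starting from compound 2 at 120 nM as the reference, no shift beyond the usual scatter is expected in either direction. The estimated change is a 1.1-fold higher number from compound 2 to compound 3 (0.03 log units; within the scatter) on this reading. For compound 3 the expected value is 130 nM with an estimated range from 45 nM to 380 nM as the working figure.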

Compound 3, half-maximal inhibitory concentration: 80 nM
For compound 3 the middle estimate is 1.6-fold (0.21 log units) above the measured one; low and high end bracket the measured number.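

For the compounds shown here, the first readable step in this assay is a 1.5-fold lower number from compound 2 to compound 3 (0.18 log units; within the scatter), and it falls on an aromatic carbon of a six-membered aromatic ring of carbon only, para to a large group. At this position, one five-membered aromatic ring with 2 hetero atoms can therefore stand in for another, with the methyl-bearing 1-methyl-1H-pyrazol-4-yl replacing 1,2-thiazol-4-yl, without a shift beyond the usual scatter. Compound 1 remains a limit and not a number, so steps involving it cannot be read: the limit of > 500 nM in this assay, at which 1 of the 3 values shown sits.

From the compounds shown here alone, whether this position also accepts a phenyl ring, a pyridine ring or a simple amine remains open. Going by these compounds, the effect of a longer chain on the pyrazole nitrogen in place of the methyl group is equally open.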